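The source may hold more compounds than are shown below. What is called first, only, known or untested is meant among the compounds shown, and "the series" means these compounds.

Notes on the series. Compound 2 `CCN(CC)S(=O)(=O)c1ccc(S(=O)(=O)N2CCC[C@@H](C(=O)N3CCC(C(F)(F)F)CC3)C2)cc1` carries a 4-(trifluoromethyl)piperidin-1-yl amide on the shared core; in a functional assay on BXPC-3 cells (Homo sapiens) for inhibition, read by MTT assay, with a stated time of 7 days (on this read-out higher numbers stand for weaker inhibition and lower numbers for stronger inhibition), compound 2 gives 370 nM, the lowest of the two numbers obtained so far. Compound 1 `CCN(CC)S(=O)(=O)c1ccc(S(=O)(=O)N2CCC[C@@H](C(=O)N[C@H]3CCOC3)C2)cc1` bears an (oxolan-3-yl)amino group on the same carbonyl carbon, and in this assay compound 1 gives 5270 nM. For the measured compounds named here, the single measured step, a 14-fold lower number from compound 1 to compound 2 (1.15 log units; beyond the scatter), is the only comparison available. Compound 3 `CCN(CC)S(=O)(=O)c1ccc(S(=O)(=O)N2CCC[C@@H](C(=O)N[C@@H]3CCOC3)C2)cc1` is still to be measured in this assay; it differs from compound 2 by (oxolan-3-yl)amino in place of 4-(trifluoromethyl)piperidin-1-yl on a carbonyl carbon. This change is the measured step run backwards, except that the (oxolan-3-yl)amino group of compound 3 and that of compound 1 differ in their defined stereocentre, for which no measurement exists. As far as these compounds go, the expected step is therefore an increase of roughly the size of the measured step reversed, a 12-fold higher number from compound 2 to compound 3 (1.09 log units; beyond the scatter), with a widened range because the stereocentre is untested and the measured step of a 14-fold lower number from compound 1 to compound 2 (1.15 log units; beyond the scatter) rests on one pair. For compound 3 the estimated value in this assay is 4500 nM, within 1500 nM to 15000 nM.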

Compound 3, half-maximal inhibitory concentration: 2270 nM
Beside the measured number, compound 3's estimate is 2.0-fold (0.30 log units) above it; the measured number falls inside the stated range.
By their numbers in this assay, from the lowest: compound 2; then compound 3; then compound 1.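

Compounds 1 and 3 show that the configuration of the (oxolan-3-yl)amino group matters on its own in this assay, with a 2.3-fold lower number from compound 1 to compound 3 (0.37 log units; beyond the scatter). The exchange on the carbonyl carbon does not depend on one configuration: a 6.1-fold higher number from compound 2 to compound 3 (0.79 log units; beyond the scatter) is also beyond the scatter, alongside a 14-fold lower number from compound 1 to compound 2 (1.15 log units; beyond the scatter), so compound 2 stays lowest against both (oxolan-3-yl)amino compounds, though the size of the step depends on which of them is compared. The gap between compound 1 and compound 3 can be assigned to that single stereocentre and to nothing else, for this reason: the fact that compounds 1 and 3 differ only in the configuration as drawn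

The exchange itself alters the ring, the fluorine content and the amide hydrogen together, so the compounds shown do not separate these parts, and it stays open whether a plain piperidin-1-yl, a morpholin-4-yl or a 4-methylpiperidin-1-yl amide would track compound 2 or the (oxolan-3-yl)amino pair. As far as these compounds go, the configuration at the saturated ring carbon of the shared core is also the same as drawn in all three compounds, so its contribution remains open.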